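The compounds below may be only part of what the source reports. "The series", "measured", "known", "first", "only" and "open" are said of these compounds alone.

Compound 2 `NC(=O)Nc1sc(-c2ccc(C(=O)N3CCOCC3)cc2)cc1C(=O)N[C@H]1CCCNC1` in a functional assay on HT-29 cells (Homo sapiens) (a higher number here means that more compound is needed for the effect, a lower number that less compound is needed), gives 610 nM, the lowest number of the two values recorded here. Its nearest neighbour is compound 1 `CS(=O)(=O)Nc1ccc(-c2cc(C(=O)N[C@H]3CCCNC3)c(NC(N)=O)s2)cc1`, which in this assay gives 2200 nM. Compound 3 `NC(=O)Nc1sc(-c2ccccc2)cc1C(=O)NC1CCOCC1` belongs to the same series; in this assay compound 3 gives "not determined" (no result reported), so no result is reported for it. Among the compounds with values here, the only measured step is a 3.6-fold lower number from compound 1 to compound 2 (0.56 log units; beyond the scatter), which traded methanesulfonamido for (morpholin-4-yl)carbonyl on the aromatic carbon and is described as a modest change beyond the scatter.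

Compound 4 `Cc1ccc(-c2cc(C(=O)N[C@H]3CCCNC3)c(NC(N)=O)s2)cc1` differs from compound 2 as follows: methyl in place of (morpholin-4-yl)carbonyl on an aromatic carbon. Within the data shown here, no measured pair covers a methyl at this position, so the step from compound 1 to compound 2 bears on it only indirectly: it shows that what sits on this aromatic carbon can move the number by a modest amount. Given that the (morpholin-4-yl)carbonyl of compound 2 is lost entirely, the expected step is a 2.5-fold higher number from compound 2 to compound 4 (0.39 log units; beyond the scatter), toward a higher number, though a result within the scatter is also plausible. Compound 4 is therefore estimated at 1500 nM, with a range of 500 nM to 4500 nM.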

Compound 4, half-maximal effective concentration: 70 nM
The estimate for compound 4 lay 21-fold (1.33 log units) above the measured number; the whole stated range lies above it.
By their numbers in this assay, from the lowest: compound 4; then compound 2; then compound 1.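

In this assay, methyl on this aromatic carbon gives an 8.7-fold lower number from compound 2 to compound 4 (0.94 log units; beyond the scatter) and a 31-fold lower number from compound 1 to compound 4 (1.50 log units; beyond the scatter), so this position can shift the number much further than the first step alone revealed. Among these three compounds, the lowest number comes with the group that has no ring and no hydrogen-bond acceptors, which shows that neither the morpholine ring nor the carbonyl of (morpholin-4-yl)carbonyl is needed for the effect in this series. Nothing available explains why methyl does so much better here.

As far as these compounds go, it remains open whether methyl is itself the best choice, or whether a longer chain such as ethyl, a halogen such as chlorine, or an amine on this carbon would give a lower or a higher number. It is also unknown how much of the gain would hold with a different amide on the shared core.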